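A few compounds are considered here, and "the series" means these few. Any claim that something is new, unique, unknown or untested is made for them only; others in the source may bear on it.

Values in a physicochemical assay for solubility, read by nephelometry, at pH 2; on this read-out lower numbers stand for lower solubility and higher numbers for higher solubility:

- compound 1 `N#Cc1cnc(NC(=O)CCCOc2ccccc2)s1`: 1100 nM
- compound 2 `N#Cc1cnc(NC(=O)CCCOc2cccc(C(F)(F)F)c2)s1`: < 1600 nM (a limit, not a number)
- compound 3 `O=C(CCCOc1ccccc1)Nc1ncc(Cl)s1`: < 1200 nM (a limit, not a number)

Compound 2 has no number of its own to start from, only the limit < 1600 nM. Compound 3 also reports only a limit, as the limit of < 1200 nM in this assay, at which 1 of the 3 values shown sits, records, and the limit of < 1600 nM in this assay, at which 1 of the 3 values shown sits, records the same for compound 2. Among the measured compounds shown here, compound 1 therefore holds the only true number in the set.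

Compound 4 `N#Cc1cnc(NC(=O)CCCOc2cccc(Cl)c2)s1` has not yet been measured. It differs from compound 2 by one change: chloro in place of trifluoromethyl on an aromatic carbon. In words, this is chloro in place of trifluoromethyl on an aromatic carbon, and the rest of the structure stays the same.

For the measured compounds named here, two measured steps bear on this change. The first, which installs the trifluoromethyl group, is a step that the limit leaves unreadable from compound 1 to compound 2. The second, which brings in chloro at another place on the shared core, is a step that the limit leaves unreadable from compound 1 to compound 3. Neither has a readable size, so neither supports a direction for the change.

No step beyond the usual scatter is therefore expected in this assay, and the expected step is a step that the limit leaves unreadable from compound 2 to compound 4. The expectation is anchored on compound 1 at 1100 nM. Another result reported only as a limit would not be surprising. For compound 4 the estimated value is 1000 nM, with an expected range from 400 nM to 1800 nM.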

Compound 4, solubility: < 1600 nM
Compound 4 gave a limit, no number (the forecaster's own chance of this, stated with the estimate: 60%); the middle value lies beyond the limit too.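

In this assay compound 4 gives < 1600 nM, a limit and not a number. The steps to compound 4 from compound 2 and from compound 1 cannot be read, so neither size nor direction follows for either change. The compounds shown leave open whether chloro in place of trifluoromethyl or hydrogen changes solubility at all.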